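A few compounds are considered here, and "the series" means these few. Any claim that something is new, unique, unknown or untested is made for them only; others in the source may bear on it.

Series notes. The first member is compound 1 `O=C1N/C(=C\c2ccc(O)cc2)C(=O)N1c1cccc(I)c1`. In a functional assay on NCI-H292 cells (Homo sapiens) for antiproliferative activity (a higher number here means a weaker inhibitor, a lower number a stronger inhibitor), compound 1 gives > 200000 nM, which is a limit of the assay and not a number. Compound 2 `O=C(O)c1cccc(N2C(=O)N/C(=C\c3ccc(O)cc3)C2=O)c1` carries carboxy on the aromatic carbon where compound 1 carries iodo. In this assay compound 2 gives > 200000 nM, again a limit. Compound 3 `O=C1N/C(=C\c2ccc(O)cc2)C(=O)N1c1cccc(Br)c1` carries bromo on that aromatic carbon. In this assay compound 3 gives > 200000 nM, also a limit. Compound 3 therefore stands level with the other two members, all three sitting at the same limit and none separated from another by a readable number. The steps among them read a step that the two limits leave unreadable from compound 1 to compound 2, a step that the two limits leave unreadable from compound 1 to compound 3 and a step that the two limits leave unreadable from compound 2 to compound 3; none of them can be sized because of the limit of > 200000 nM in this assay, at which 3 of the 3 values shown sit.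

The next member is compound 4 `O=C(NCC1CCCCC1)c1cccc(N2C(=O)N/C(=C\c3ccc(O)cc3)C2=O)c1`. The change from compound 3 is (cyclohexylmethyl)carbamoyl in place of bromo on an aromatic carbon. All three measured steps bear on this change in that each also exchanges the substituent on this aromatic carbon, yet each is unreadable, so neither a direction nor a size beyond the scatter can be taken from them; the entering group is larger than anything tried so far in the series.

For compound 4 the expected value in this assay is 100000 nM, with a range from 20000 nM to 300000 nM. The estimated step is an at least 2.0-fold lower number from compound 3 to compound 4 (0.30 log units; that floor lies within the scatter).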

Compound 4, half-maximal inhibitory concentration: 17900 nM
Compound 4: the middle estimate sits 5.6-fold (0.75 log units) above what was measured, and the stated range ends above it.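

In this assay, the aromatic carbon that held iodo, bromo or carboxy gives the series its first readable change, after the exchanges among compounds 1, 2 and 3 could not be read. Putting (cyclohexylmethyl)carbamoyl in place of bromo gives an at least 11-fold lower number from compound 3 to compound 4 (1.04 log units; beyond the scatter), and the same group in place of iodo gives an at least 11-fold lower number from compound 1 to compound 4 (1.04 log units; beyond the scatter), while (cyclohexylmethyl)amino in place of hydroxy on the carbonyl carbon of compound 2 gives an at least 11-fold lower number from compound 2 to compound 4 (1.04 log units; beyond the scatter), so a substituted amide at this position separates from all three earlier members. Each of these steps is a floor and not a full size, because the earlier members supply no number to start from: the limit of > 200000 nM in this assay, at which 3 of the 4 values shown sit.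

On these data alone, how the step divides among the amide, the methylene link and the cyclohexyl ring stays open, and an unsubstituted carbamoyl, a methylcarbamoyl, a benzylcarbamoyl or a cyclohexylmethyl ester on the same aromatic carbon would start to separate these parts. Also open, as far as these compounds go, is whether the hydroxy on the other aromatic ring of the shared core matters to this step, which a methoxy or a fluoro in its place alongside the (cyclohexylmethyl)carbamoyl would address.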